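Isopropyl in place of methyl on compound 2

The source may hold more compounds than are shown below. What is called first, only, known or untested is meant among the compounds shown, and "the series" means these compounds.

Values in a functional assay on DU-145 cells (Homo sapiens) for inhibition, read by MTT assay, with a stated time of 48 h; on this read-out higher numbers stand for weaker inhibition and lower numbers for stronger inhibition:
- compound 1 `Cn1c(/C=C2\SC(=O)N(CC(=O)Nc3cc(C(C)(C)C)on3)C2=O)nc2ccccc21`: 31400 nM
- compound 2 `Cn1c(/C=C2\SC(=O)N(CC(=O)N3CCCCC3)C2=O)nc2ccccc21`: > 50000 nM (a limit)
- compound 3 `Cn1c(/C=C2\SC(=O)N(CC(=O)N3CCCC3)C2=O)nc2ccccc21`: > 50000 nM (a limit)

Compound 2 gives > 50000 nM, which is a limit and not a number. Compound 3 gives > 50000 nM, also a limit. These two values make up (the limit of > 50000 nM in this assay, at which 2 of the 3 values shown sit). Only compound 1 returns an actual number.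

The next compound, compound 4 `CC(C)n1c(/C=C2\SC(=O)N(CC(=O)N3CCCCC3)C2=O)nc2ccccc21`, differs from compound 2 in one place: isopropyl in place of methyl on an aromatic nitrogen. In words, this is isopropyl in place of methyl on an aromatic nitrogen.

The measured steps all concern the group on the carbonyl carbon, not this nitrogen. They are an at least 1.5-fold higher number from compound 1 to compound 2 (0.20 log units; that floor lies within the scatter), an at least 1.5-fold higher number from compound 1 to compound 3 (0.20 log units; that floor lies within the scatter) and a step that the two limits leave unreadable from compound 2 to compound 3. None of them gives a direct size for the present change, and the first two are only floors.

The starting point is compound 2 with its limit of > 50000 nM, so no step beyond the scatter is expected in this assay. The expected step is a number no higher from compound 2 to compound 4 (the limit leaves the size open). For compound 4 the estimated value is 50000 nM. The expected range for compound 4 runs from 20000 nM to 120000 nM, and a report of only a limit is the likelier outcome.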

Compound 4, half-maximal inhibitory concentration: 42200 nM
Beside the measured number, compound 4's estimate is 1.2-fold (0.07 log units) above it, and the stated range covers the measured number.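

In this assay, among these compounds, the aromatic nitrogen becomes a tested position for the first time, since all earlier steps concerned the group on the carbonyl carbon. With piperidin-1-yl held constant, isopropyl in place of methyl on this nitrogen gives an at least 1.1-fold lower number from compound 2 to compound 4 (0.07 log units; that floor lies within the scatter); this change yields a readable number, but the step is only a floor within the scatter and shows no real gain in inhibition. Compound 2 gives > 50000 nM, which is a limit and not a number, so the true size of the step stays unknown, and that limit is a common one in the series: the limit of > 50000 nM in this assay, at which 2 of the 4 values shown sit.

On these data alone, it remains open whether a longer chain such as n-butyl, or a benzyl group, on this aromatic nitrogen would move the value beyond the scatter, and whether an amine or a carboxylic acid at the end of such a chain would do so. As far as these compounds go, it is also open whether isopropyl would have any comparable effect when paired with pyrrolidin-1-yl or (5-(tert-butyl)-1,2-oxazol-3-yl)amino on the carbonyl carbon.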